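Ester series, whole-animal read-out: cyano to methyl

A few compounds are considered here, and "the series" means these few. Any claim that something is new, unique, unknown or untested is made for them only; others in the source may bear on it.

Measured so far:
compound 1 `CN1CCC(OC(=O)c2ccc(C#N)cc2)CC1` — 1.65
compound 2 `Cc1ccc(C)c(C(=O)OC2CCN(C)CC2)c1` — 1.36

In a functional assay on the whole organism with Mus musculus as the target (on this read-out higher numbers stand for higher potency (the scale is a negative logarithm) and lower numbers for lower potency), compound 1 gives 1.65. Of the two numbers shown this is the higher, but compound 2 at 1.36 lies within the scatter of it, so the two compounds are not told apart on this read-out.

Compound 3 `Cc1ccc(C(=O)OC2CCN(C)CC2)cc1` has not been measured. It differs from compound 1 by methyl in place of cyano on an aromatic carbon. For the measured compounds named here, no step between two measured compounds exists to calibrate such a change, so the expectation rests on the two values alone. Compound 2, which carries methyl groups and no cyano, gives 1.36, close to compound 1; a change of at most the scatter is therefore expected, with no clear direction. Compound 3 is estimated at 1.45, with a range from 1 to 1.9. The expected step of a number 0.20 log units lower from compound 1 to compound 3 (within the scatter) stays within the scatter.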

Compound 3, logarithm of the reciprocal of the active concentration, log(1/C): 1.17
Estimate against measurement, compound 3: 0.28 log units above; measured number inside the range.
By their numbers in this assay, from the lowest: compounds 3, 2 and 1 (each within the scatter of the next, the first and the last beyond it).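

In this assay, for the compounds shown here, methyl in place of cyano on the aromatic carbon para to a large group gives a number 0.48 log units lower from compound 1 to compound 3 (beyond the scatter), the first step that isolates a single change. This position is therefore not indifferent to the group it carries, at least for this pair, something the values of compounds 1 and 2 could not show, as those two compounds differ in more than one place. Nothing at hand bears on what lies behind this step.

As far as these compounds go, how a carboxylic acid, a primary amide or a longer alkyl chain would read at this position remains open. Also open, from the compounds shown here alone, is whether the same exchange of cyano for methyl gives a similar step elsewhere on the ring, as a single pair carries the present reading.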